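Removing One Bromine from the Strongest Compound

The source may hold more compounds than are shown below. What is called first, only, known or untested is meant among the compounds shown, and "the series" means these compounds.

Compound 1 `COc1cc(N)c(Cl)cc1C(=O)CCC1CCN(CCNS(=O)(=O)c2cc(Br)c(N)c(Br)c2)CC1` is the starting point. In an assay on HEK293 cells for displacement of a labelled ligand from 5-hydroxytryptamine receptor 6 (Homo sapiens), with a stated time of 60 min, tested at 1 uM, in the presence of a further agent that is not named here (a lower number here means a weaker effect, a higher number a stronger effect of the compound at the concentration tested), compound 1 gives 83%, the highest of the three numbers shown. Compound 2 `COc1ccc(S(=O)(=O)NCCN2CCC(CCC(=O)c3cc(Cl)c(N)cc3OC)CC2)c(OC)c1` gives 45%, and compound 3 `COc1ccc(S(=O)(=O)CCCN2CCC(CCC(=O)c3cc(Cl)c(N)cc3OC)CC2)cc1` gives 33%. Within the data shown here, the only single-place step measured, a number 38 percentage points lower from compound 1 to compound 2 (beyond the scatter), swaps the whole aryl group on the sulfonyl sulfur, so it shows that changes on that group can move the number a great deal, but it does not test the loss of one bromo alone. Compound 4 `COc1cc(N)c(Cl)cc1C(=O)CCC1CCN(CCNS(=O)(=O)c2ccc(N)c(Br)c2)CC1` differs from compound 1 by hydrogen in place of bromo on an aromatic carbon. Among the measured compounds shown here, with no direct precedent, a modest decrease in this assay is expected, a number 13 percentage points lower from compound 1 to compound 4 (beyond the scatter). Compound 4 is therefore estimated at 70%, within 50% to 88%.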

Compound 4, a percentage reported as inhibition, at one concentration (the size of the read-out at that concentration, not a potency): 85%
Estimate against measurement, compound 4: 15 percentage points below, within the range that was stated.
By their numbers in this assay, from the lowest: compound 3; then compound 2; then compounds 1 and 4 (each within the scatter of the next).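

In this assay, the change from 4-amino-3,5-dibromophenyl to 4-amino-3-bromophenyl gives a number 2 percentage points higher from compound 1 to compound 4 (within the scatter), so the second bromo is not needed to keep this read-out in these two compounds. With one bromo and the amino group kept on the ring, the change from the 2,4-dimethoxyphenyl group gives a number 40 percentage points higher from compound 2 to compound 4 (beyond the scatter), which shows that the large gap does not depend on having both bromo groups. No measured evidence here explains this result. From the compounds shown here alone, it remains open whether the remaining bromo can also be replaced by hydrogen, fluoro or methyl. Going by these compounds, the role of the amino group, and the effect of replacing it with a hydroxyl group, also remain open.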